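This account rests on a few compounds, and the source may have more. Where it says the series, first, only, none or still open, it means among the compounds named here.

Measured so far:
- compound 1 `Cc1cc(Nc2cc(-c3ccccc3)[nH]n2)n2nc(SCc3ccc(F)cc3)nc2n1` — 8110 nM
- compound 2 `Cc1cc(Nc2ccn(Cc3nc(C)c4ccccc4n3)n2)n2nc(SCc3ccc(Br)cc3)nc2n1` — 5450 nM

Both numbers come from a functional assay on PC-9 cells (Homo sapiens) for inhibition, read by MTT assay, with a stated time of 72 h; on this read-out higher numbers stand for weaker inhibition and lower numbers for stronger inhibition. Compound 1 gives 8110 nM, the higher of the two; compound 2 gives 5450 nM, and the gap between the two lies within the scatter, so no order can be read from it. Compound 3 `COc1ccc(CSc2nc3nc(C)cc(Nc4cc(-c5ccccc5)[nH]n4)n3n2)cc1` is not yet measured. It differs from compound 1 in one place: methoxy in place of fluoro on an aromatic carbon. For the measured compounds named here, no measured pair shows this change, so the expected step from compound 1 to compound 3 in this assay, a 1.2-fold lower number from compound 1 to compound 3 (0.06 log units; within the scatter), is nothing beyond the scatter in either direction. Compound 3 is estimated at 7000 nM, within 3000 nM to 16000 nM.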

Compound 3, half-maximal inhibitory concentration: 8110 nM
The estimate for compound 3 lay 1.2-fold (0.06 log units) below the measured number; measured number inside the range.
By their numbers in this assay, from the lowest: compounds 2, 1 and 3 (each within the scatter of the next).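

In this assay, methoxy in place of fluoro on the aromatic carbon para to a large group gives no change at the digits printed from compound 1 to compound 3 (within the scatter). For the compounds shown here, this is the first comparison that differs in one place, and it shows that this exchange, which adds a hydrogen-bond acceptor, does not separate the two compounds on this read-out. Nothing available accounts for this result.

Still open, on these data alone, is whether an amine or a carboxylic acid on this aromatic carbon would move the number beyond the scatter. A longer chain in place of the (4-fluorobenzyl)sulfanyl group is equally untested in the compounds shown.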